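This account rests on a few compounds, and the source may have more. Where it says the series, first, only, none or still open, it means among the compounds named here.

Measured so far:

Compound 1, `CN(C)CCn1cnnc1-c1cc(Oc2ccc(NC(=O)N/N=C/c3cc(C(C)(C)C)cc(C(C)(C)C)c3O)cc2F)ccn1`: in a functional assay on NCI-H460 cells (Homo sapiens) for cytotoxicity, read by MTT assay, with a stated time of 72 h (a lower number here means a stronger inhibitor, a higher number a weaker inhibitor), compound 1 gives 590 nM.
Compound 2, `CN(C)CCn1cnnc1-c1cc(Oc2ccc(NC(=O)N/N=C/c3ccccc3O[N+](=O)[O-])cc2F)ccn1`: compound 2 gives 1270 nM.

Among these two results, compound 2 gives the higher number, so it is the weaker of the pair, and the gap to compound 1 lies beyond the usual scatter of repeated measurements. Compound 3, `CN(C)CCn1cnnc1-c1cc(Oc2ccc(NC(=O)N/N=C/c3ccc(O)c(F)c3)cc2F)ccn1`, has not yet been measured. It differs from compound 2 in a single place, at the carbon that carries the double bond to nitrogen: 3-fluoro-4-hydroxyphenyl in place of 2-(nitrooxy)phenyl on a carbon with a double bond to nitrogen. For the measured compounds named here, the two compounds measured so far give no direct guide to this exact swap, so the expectation rests on their spread alone. The step from compound 2 to compound 3 is expected to be small, a 1.3-fold lower number from compound 2 to compound 3 (0.10 log units; within the scatter), toward a slightly lower number and within the scatter. Compound 3 is therefore estimated at 1000 nM, with a range from 400 nM to 2800 nM.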

Compound 3, half-maximal inhibitory concentration: 2620 nM
Estimate against measurement, compound 3: 2.6-fold (0.42 log units) below, within the range that was stated.
By their numbers in this assay, from the lowest: compound 1; then compound 2; then compound 3.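

In this assay, putting 3-fluoro-4-hydroxyphenyl in place of 2-(nitrooxy)phenyl on the carbon with a double bond to nitrogen gives a 2.1-fold higher number from compound 2 to compound 3 (0.31 log units; beyond the scatter), a modest step. This shows that the number responds to the group at this place, and that this particular exchange does not lower it. The exchange alters several things at once, since the entering group brings a fluorine and a hydrogen-bond donor while the leaving group carries the nitrooxy unit, and no measurement here explains the step or assigns it to any one of these parts.

On these data alone, whether the fluorine or the hydroxyl matters more remains open. So does what a plain phenyl ring, or a phenyl ring bearing an amine or a carboxylic acid, would give at this carbon.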